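The compounds below may be only part of what the source reports. "The series", "measured", "known", "first", "only" and "open" are said of these compounds alone.

In a functional assay on LOX cells (Homo sapiens) for antiproliferative activity, read by WST assay, with a stated time of 3 days (a higher number here means a weaker inhibitor, a lower number a stronger inhibitor), compound 1 `O=c1[nH]c(=O)n([C@@H]2O[C@H](CO)[C@@H](O)[C@H]2O)c(I)c1F` gives > 50000 nM, which is a limit of the assay and not a number. Going by the values given here, compound 2 `Nc1c(F)c(=O)[nH]c(=O)n1[C@@H]1O[C@H](CO)[C@@H](O)[C@H]1O`, at 3400 nM, holds the only actual number so far. Compound 3 `CCc1c(F)c(=O)[nH]c(=O)n1[C@@H]1O[C@H](CO)[C@@H](O)[C@H]1O` differs from it by ethyl in place of amino on an aromatic carbon. As amino leaves again, a higher number is expected in this assay, given the large at least 14-fold lower number from compound 1 to compound 2 (1.16 log units; beyond the scatter), which lies beyond the scatter and brought amino in place of iodo. The expected move is sizeable: a 5.9-fold higher number from compound 2 to compound 3 (0.77 log units; beyond the scatter). For compound 3 the estimated value is 20000 nM, within a range of 5000 nM to 50000 nM.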

Compound 3, half-maximal inhibitory concentration: 4500 nM
Estimate against measurement, compound 3: 4.4-fold (0.65 log units) above; the measured number lies below the stated range.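

Amino is not needed at this position: in this assay, ethyl in place of amino gives a 1.3-fold higher number from compound 2 to compound 3 (0.12 log units; within the scatter), although ethyl has 0 hydrogen-bond donors against 1 for amino. The drop in the number from iodo is therefore not tied to amino, since ethyl also gives an at least 11-fold lower number from compound 1 to compound 3 (1.04 log units; beyond the scatter). Compound 1 stands at a limit and not at a number, so this step has no exact size: the limit of > 50000 nM in this assay, at which 1 of the 3 values shown sits.

Going by these compounds, what remains open is whether a longer chain, a methoxy group or a carboxylic acid at this position would keep the number near those of compound 2 and compound 3.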